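Hydroxy in Place of Chloro on a Hydrazone Core

A few compounds are considered here, and "the series" means these few. Any claim that something is new, unique, unknown or untested is made for them only; others in the source may bear on it.

Going by the values given here, compound 1 `O=C(N/N=C/c1cccc(Cl)c1)c1cccnc1` is the one member of this small set with a full number in an ADME assay on HEL cells (Homo sapiens) for cytotoxicity, read by microscopy; on this read-out higher numbers stand for lower toxicity in this test and lower numbers for higher toxicity in this test. In this assay compound 1 gives 53 ug/mL. Compound 2 `O=C(N/N=C/c1ccc([N+](=O)[O-])cc1)c1cccnc1` is the other measured compound. In this assay compound 2 gives < 0.16 ug/mL, and that entry is a limit of the test rather than a number. Among the compounds with values here, compound 1 therefore stands at the only finite value shown, whereas the remaining entry sits at the limit of < 0.16 ug/mL in this assay, at which 1 of the 2 values shown sits. Within the data shown here, no step between two measured compounds can be drawn, since compound 1 and compound 2 differ in more than one place; of that pair only the two values themselves can be stated.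

Compound 3 `O=C(N/N=C/c1cccc(O)c1)c1cccnc1` has not yet been measured. It differs from compound 1 by hydroxy in place of chloro on an aromatic carbon. Among the measured compounds shown here, with no measured step of this kind to lean on, the expected change in this assay is small, if anything toward lower toxicity, and may well lie within the scatter. Compound 3 is expected to give about 80 ug/mL in this assay, between 25 ug/mL and 250 ug/mL. This estimate means an expected step of a 1.5-fold higher number from compound 1 to compound 3 (0.18 log units; within the scatter).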

Compound 3, half-maximal cytotoxic concentration: > 100 ug/mL
Compound 3 was reported as a limit; the forecaster's own chance of this, stated with the estimate: 30%; middle value at least 1.2-fold (0.09 log units) from the limit.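

Going by these compounds alone, the first measured change at this place, on an aromatic carbon of the six-membered ring and meta to a large group, replaces chloro with hydroxy, and in this assay it gives an at least 1.8-fold higher number from compound 1 to compound 3 (0.27 log units; that floor lies within the scatter). Compound 3 stands at a limit of the test and not at a number: the limit of > 100 ug/mL in this assay, at which 1 of the 3 values shown sits. The earlier compounds shown here offered no step at all, whereas this one shows that the exchange, which brings in a hydrogen-bond donor and a hydrogen-bond acceptor where chloro had neither, does not move the read-out toward higher toxicity, although its floor alone does not establish a real rise.

Going by these compounds, how far the true value of compound 3 lies past that limit stays open, so the full size of the step remains unknown, and the two compounds alone cannot tell whether the outcome belongs to hydroxy itself or to the loss of chloro. Whether an amine, a methoxy group or a carboxylic acid on the same aromatic carbon would read like hydroxy is also left open, as is whether the exchange would behave the same way on a different core.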